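Serum half-life after one change on the amine nitrogen

A few compounds are considered here, and "the series" means these few. Any claim that something is new, unique, unknown or untested is made for them only; others in the source may bear on it.

Of the compounds shown here, three have been measured in an ADME assay on a cell-free system (serum) for metabolic stability (a lower number here means that the compound disappears faster, a higher number that the compound lasts longer), so far. Compound 1 (`CC(C)(C)c1cc(OC(=O)/C=C/c2ccccc2)ccc1O`) gives < 0.25 h as a limit of the assay. Compound 2 (`CC(C)(C)c1cc(OC(=O)c2ccco2)ccc1O`) gives < 0.25 h as a limit of the assay too. Among the measured compounds shown here, compound 3 (`CC(C)(C)c1cc(NC(=O)c2c(Cl)cc(NCc3ccncc3)cc2Cl)ccc1O`) gives > 1 h as a limit of the assay, the only one of the three values on that side. Compound 4 (`CC(C)(C)c1cc(NC(=O)c2c(Cl)cc(NC3CCCC3)cc2Cl)ccc1O`) carries cyclopentyl in place of (pyridin-4-yl)methyl on a nitrogen on an aromatic ring. For the measured compounds named here, no measured pair shows this change, so the expected step that the limit leaves unreadable from compound 3 to compound 4 is none beyond the scatter, in neither direction. Compound 4 is estimated at 2 h with an expected range from 1 h to 5 h for its half-life.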

Compound 4, half-life: > 1 h
Compound 4: no number, only a limit; the forecaster's own chance of this, stated with the estimate: 65%; the middle value is on the limit's open side.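

Among the compounds shown here, compound 3 and compound 4 both give only a limit of the assay in this assay, and no step between them can be read. The compounds shown leave open whether cyclopentyl in place of (pyridin-4-yl)methyl changes the half-life at all.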